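Trifluoromethyl for Methoxy: Expecting Another Limit

The compounds below may be only part of what the source reports. "The series", "measured", "known", "first", "only" and "open" are said of these compounds alone.

Of the compounds shown here, three have been tested in an ADME assay on Raji cells (Homo sapiens) for cytotoxicity, read by CellTiter-Glo and resazurin assay, with a stated time of 72 h; a lower number here means that less compound is needed, a higher number that more compound is needed for the effect. Each result is a limit of the assay rather than a number.

Compound 1 `CC(C)N(Cc1cccc(OCCCCCC(=O)O)c1)C(=O)c1ccc(-c2cccc(OCc3ccccc3)c2)cc1`: > 26000 nM
Compound 2 `COc1cccc(-c2ccc(C(=O)N(Cc3cccc(OCCCCCC(=O)O)c3)C(C)C)cc2)c1`: > 20900 nM
Compound 3 `CC(C)N(Cc1cccc(OCCCCCC(=O)O)c1)C(=O)c1ccc(-c2cc3ccccc3n2S(=O)(=O)c2ccccc2)cc1`: > 26000 nM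

Compound 2 stands at the limit of > 20900 nM in this assay, at which 1 of the 3 values shown sits. Compounds 1 and 3 stand at the limit of > 26000 nM in this assay, at which 2 of the 3 values shown sit. Going by the values given here, because all three results are limits, the step that the two limits leave unreadable from compound 1 to compound 2 cannot be read; it shows only that both compounds lie beyond the range the assay reports as numbers. Among the compounds with values here, no pair involving compound 3 has a step recorded, and its limit, like the others, says only that the measured effect was not reached.

The next compound, compound 4 `CC(C)N(Cc1cccc(OCCCCCC(=O)O)c1)C(=O)c1ccc(-c2cccc(C(F)(F)F)c2)cc1`, differs from compound 2 by trifluoromethyl in place of methoxy on an aromatic carbon; read one bond further out, 3-methoxyphenyl becomes 3-(trifluoromethyl)phenyl. Within the data shown here, no measured step bears on this change with a readable size, since the only step available is unreadable. Among the measured compounds shown here, with every value so far sitting at a limit and no step pointing in either direction, nothing beyond the scatter is expected.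

Compound 4 is therefore expected to give about 30000 nM, in the range 12000 nM to 80000 nM, most likely reported again as a limit; the expected step that the limit leaves unreadable from compound 2 to compound 4 is essentially none.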

Compound 4, half-maximal effective concentration: > 26000 nM
Compound 4: only a limit was reported (the forecaster's own chance of this, stated with the estimate: 85%); the middle value is on the limit's open side.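

In this assay compound 4 gives > 26000 nM, which is a limit of the assay and not a number. Compound 1 and compound 2 also gave limits, so neither of their steps to compound 4 can be read. Still open is where the true values of these compounds lie, and whether trifluoromethyl in place of methoxy changes them at all.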